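A few compounds are considered here, and "the series" means these few. Any claim that something is new, unique, unknown or untested is made for them only; others in the source may bear on it.

Of the compounds shown here, two carry numbers so far. In an assay on CHO cells for displacement of a labelled ligand from adenosine receptor A1 (Homo sapiens), read by scintillation counting, with a stated time of 60 min, tested at 10 uM (on this read-out higher numbers stand for more inhibition at the one concentration tested (going by the name of the read-out) and lower numbers for less inhibition), compound 1 `N=c1oc2ccc(Br)cc2cc1C(=O)NC1CCCCC1` gives 5%. In this assay compound 2 `COCCNC(=O)c1cc2cc(Cl)ccc2oc1=N` gives 17%. Compound 1 therefore stands lowest of the two numbers, and the gap to compound 2 lies beyond the usual scatter of the method, so compound 2 shows the larger inhibition of the pair. Among the compounds with values here, no step between measured compounds isolates a single change, so nothing yet shows how an alteration on the amide-type nitrogen plays out.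

Compound 3 `N=c1oc2ccc(Br)cc2cc1C(=O)NCC(O)CO` has not been measured in this assay. It differs from compound 1 in one place: 2,3-dihydroxypropyl in place of cyclohexyl on an amide-type nitrogen. The core of compound 1 is kept throughout.

Within the data shown here, with no comparable step on record, the expectation rests on the low starting point of compound 1 alone, its 5% leaving little room downward. A step of modest size is expected, if any, and none clearly beyond the scatter: a number 3 percentage points higher from compound 1 to compound 3 (within the scatter). Compound 3 is accordingly estimated at 8% in this assay, with a range from 0% to 25%.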

Compound 3, a percentage reported as inhibition, at one concentration (the size of the read-out at that concentration, not a potency): 11%
The estimate for compound 3 lay 3 percentage points below the measured number, within the range that was stated.
By their numbers in this assay, from the lowest: compounds 1, 3 and 2 (each within the scatter of the next, the first and the last beyond it).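

In this assay, within the data shown here, 2,3-dihydroxypropyl in place of cyclohexyl on the amide-type nitrogen gives a number 6 percentage points higher from compound 1 to compound 3 (within the scatter), and this is the first step that isolates a single change. The exchange is large in what it counts, since a six-membered non-aromatic ring of carbon only, with no hydrogen-bond donors or acceptors, leaves and an open chain with 2 hydrogen-bond donors and 2 hydrogen-bond acceptors enters, yet the two readings cannot be told apart at this position, so this one pair shows no sensitivity of the read-out to the change. No measurement on record bears on why the step has this size.

Still open, on these data alone, is whether any group on this nitrogen gives a step beyond the scatter from compound 1, for instance an aminoethyl chain, a carboxylic acid on a short chain, a longer alkyl chain or a phenyl ring. A single step also cannot say whether the ring or the hydroxyl groups of these two substituents matter on their own, which a plain propyl chain or a hydroxycyclohexyl group would begin to separate.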